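The source may report more compounds than this note shows. Statements on the series, on what has been measured and on what is new or still open speak of the compounds shown alone.

In a functional assay on A549 cells (Homo sapiens) for inhibition, read by MTT assay, with a stated time of 48 h (on this read-out higher numbers stand for weaker inhibition and lower numbers for stronger inhibition), the measured compounds give the following numbers:

compound 1, `COc1ccc2c(=O)c(/C=C/C(=O)NCc3ccccc3)coc2c1`: 11800 nM
compound 2, `COc1ccc2c(=O)c(/C=C/C(=O)NCc3cccc(F)c3)coc2c1`: 26900 nM
compound 3, `COc1ccc(CNC(=O)/C=C/c2coc3cc(OC)ccc3c2=O)cc1`: 22500 nM

Within this set compound 3 stands second highest of the three numbers; its nearest neighbour is compound 2, with a 1.2-fold lower number from compound 2 to compound 3 (0.08 log units; within the scatter), and its furthest is compound 1, with a 1.9-fold higher number from compound 1 to compound 3 (0.28 log units; within the scatter). Going by the values given here, the one step beyond the scatter is a 2.3-fold higher number from compound 1 to compound 2 (0.36 log units; beyond the scatter).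

Compound 4, `COc1ccc2c(=O)c(/C=C/C(=O)Nc3ccccc3C)coc2c1`, differs from compound 3 in one place: 2-methylphenyl in place of 4-methoxybenzyl on an amide-type nitrogen. Among the compounds with values here, none of the measured steps covers this change closely. The nearest is the reverse of the methoxy addition seen in a 1.9-fold higher number from compound 1 to compound 3 (0.28 log units; within the scatter), which stayed within the scatter, and the swap of one arene for another in a 1.2-fold lower number from compound 2 to compound 3 (0.08 log units; within the scatter), also within the scatter. On that basis the change from compound 3 to compound 4 is expected to give no step beyond the scatter, a 1.5-fold lower number from compound 3 to compound 4 (0.18 log units; within the scatter). Compound 4 is therefore estimated at 15000 nM in this assay, with a range from 5000 nM to 45000 nM.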

Compound 4, half-maximal inhibitory concentration: 23400 nM
The estimate for compound 4 lay 1.6-fold (0.19 log units) below the measured number; the range from low to high includes it.
By their numbers in this assay, from the lowest: compounds 1, 3, 4 and 2 (each within the scatter of the next, the first and the last beyond it).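

In this assay the change on the amide-type nitrogen proves larger in structure than in effect: compound 4 carries 2-methylphenyl directly on that nitrogen, yet all three new steps lie within the scatter (a 1.0-fold higher number from compound 3 to compound 4 (0.02 log units; within the scatter)) (a 1.1-fold lower number from compound 2 to compound 4 (0.06 log units; within the scatter)) (a 2.0-fold higher number from compound 1 to compound 4 (0.30 log units; within the scatter)). The earlier compounds shown here varied only the substituent on a benzyl group, whereas this result shows that the number stays in the same range when the benzyl group gives way to a 2-methylphenyl group, even with the one hydrogen-bond acceptor of 4-methoxybenzyl gone. Nothing available explains why this position responds so little.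

The compounds shown leave open whether plain phenyl on this nitrogen would match 2-methylphenyl, so the methyl group cannot be judged alone. They also leave open whether an amine or a carboxylic acid on this ring, or a longer chain to it, would give a step beyond the scatter.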